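A few compounds are considered here, and "the series" means these few. Any claim that something is new, unique, unknown or untested is made for them only; others in the source may bear on it.

Compound 1, `Nc1nc(NC2CC2)c2ncn(/C=C3/CC3(CO)CO)c2n1`, gives in an ADME assay on HFF cells (Homo sapiens) for cytotoxicity, with a stated time of 8 days (on this read-out higher numbers stand for lower toxicity in this test and lower numbers for higher toxicity in this test), a reading that is a limit of the assay, > 300000 nM.
Compound 2, `CCCNc1nc(N)nc2c1ncn2/C=C1/CC1(CO)CO`, gives in this assay a reading that is likewise a limit, > 300000 nM.
Compound 3, `CCCCNc1nc(N)nc2c1ncn2/C=C1/CC1(CO)CO`, gives in this assay a reading that is also a limit, > 300000 nM.

Compound 3 therefore stands at the limit of the assay, and all three measured values sit there together (the limit of > 300000 nM in this assay, at which 3 of the 3 values shown sit). The steps among them, a step that the two limits leave unreadable from compound 1 to compound 2, a step that the two limits leave unreadable from compound 1 to compound 3 and a step that the two limits leave unreadable from compound 2 to compound 3, cannot be sized for that reason.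

Compound 4, `CCCSc1nc(N)nc2c1ncn2/C=C1/CC1(CO)CO`, differs from compound 3 by propylsulfanyl in place of butylamino on an aromatic carbon. For the measured compounds named here, none of the measured steps exchanges a nitrogen for a sulfur at this position; they only vary the alkyl on the nitrogen, and even those steps are unreadable. So no measured step bears directly on the change, and nothing in the data points to toxicity appearing where none was seen. The expectation for compound 4 in this assay is accordingly no step beyond the scatter, with the reading most likely again a limit: the estimated step is a number no higher from compound 3 to compound 4 (the limit leaves the size open). Compound 4 is thus estimated at 300000 nM, between 100000 nM and 300000 nM.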

Compound 4, half-maximal cytotoxic concentration: > 300000 nM
Compound 4 was reported as a limit (the forecaster's own chance of this, stated with the estimate: 85%); the middle value lies on the limit itself.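

Compound 4 joins compound 1, compound 2 and compound 3 at the limit of this assay, so none of the steps from those compounds to compound 4 can be read: the limit of > 300000 nM in this assay, at which 4 of the 4 values shown sit.

The compounds shown leave open whether propylsulfanyl in place of butylamino, or any other change among them, alters the reading in this assay at all.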